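The compounds below may be only part of what the source reports. "The series", "measured", "known", "first", "only" and "open" are said of these compounds alone.

Measured so far:
- compound 1, `O=C(CCc1ccccc1)Nc1nc2ccccc2c(=O)s1`: in an in vitro assay on cells for inhibition of Amine oxidase [flavin-containing] B (Homo sapiens), read by fluorescence and Amplex Red, with stated times of 30 min and 45 min (on this read-out lower numbers stand for stronger inhibition and higher numbers for weaker inhibition), compound 1 gives 17.6 nM
- compound 2, `Cc1sc2nc(NC(=O)CCCc3ccccc3)sc(=O)c2c1C`: compound 2 gives 9.8 nM
- compound 3, `COc1cccc(CCCC(=O)Nc2nc3ccccc3c(=O)s2)c1`: compound 3 gives 389 nM

Compound 1 holds the second highest of the three numbers. Its nearest neighbour is compound 2, whose number lies within the usual scatter of that of compound 1, so the two cannot be told apart on these data. Compound 3 is the furthest away, with a number beyond the scatter and on the weaker side; the two pairs differ in more than one place, so no single structural step can be read from them.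

Compound 4, `O=C(CCc1ccccc1Br)Nc1nc2ccccc2c(=O)s1`, has not yet been measured. It differs from compound 1 by bromo in place of hydrogen on an aromatic carbon, ortho to a large group. Among the measured compounds shown here, no measured pair isolates such a change, so the expected step in this assay is small, none beyond the scatter, in either direction. Compound 4 is estimated at 20 nM, with a range from 6 nM to 65 nM. The step of a 1.1-fold higher number from compound 1 to compound 4 (0.06 log units; within the scatter) that this estimate means is expected to stay within the scatter.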

Compound 4, half-maximal inhibitory concentration: 2.09 nM
Compound 4: middle estimate off by 9.6-fold (0.98 log units), on the high side, outside the stated range (below it).
By their numbers in this assay, from the lowest: compound 4; then compounds 2 and 1 (each within the scatter of the next); then compound 3.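

In this assay, among the compounds shown here, phenyl to 2-bromophenyl gives an 8.4-fold lower number from compound 1 to compound 4 (0.93 log units; beyond the scatter), the first step that changes one place only. It shows that this aromatic carbon, ortho to a large group, is not a silent position: one bromine atom in place of hydrogen, adding no ring, no hydrogen-bond donor or acceptor and no net charge, moves the number beyond the scatter towards stronger inhibition. No measurement shown here accounts for the size of this step.

As far as these compounds go, whether the step belongs to bromo itself or would also appear with chloro or methyl on the same carbon remains open. Also open, from the compounds shown here alone, is whether the same change holds on a longer chain or on the core of compound 2.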